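Ethyl ester of compound 2 in a cytotoxicity assay

The source may hold more compounds than are shown below. What is called first, only, known or untested is meant among the compounds shown, and "the series" means these compounds.

Compound 1 `COc1ccc(C2=C(c3cc(OC)c(OC)c(OC)c3)C(=O)C(OC(C)=O)C2)cc1OC(C)C`: > 100 ug/mL
Compound 2 `COc1cc(C2=C(c3ccc(OCC(=O)O)cc3)C(O)CC2=O)cc(OC)c1OC`: > 100 ug/mL

Both compounds were tested in an ADME assay on HEK293 cells (Homo sapiens) for cytotoxicity, read by MTT assay, with a stated time of 72 h; a higher number here means a weaker inhibitor, a lower number a stronger inhibitor. For compound 2, the reading of > 100 ug/mL is a limit of the assay and not a number. Compound 2 thus stands at the limit of > 100 ug/mL in this assay, at which 2 of the 2 values shown sit. Compound 3 `CCOC(=O)COc1ccc(C2=C(c3cc(OC)c(OC)c(OC)c3)C(=O)CC2O)cc1` has not yet been measured. It carries ethyl in place of hydrogen on an oxygen next to a carbonyl group, carboxy to ethoxycarbonyl (ethyl in place of hydrogen on an oxygen next to a carbonyl group). For the measured compounds named here, no measured pair gives the size of this change, so only a small shift toward a lower number is expected, with an at least 1.1-fold lower number from compound 2 to compound 3 (0.04 log units; that floor lies within the scatter) as the estimated step. For compound 3 the estimate is 90 ug/mL, with an expected range of 30 ug/mL to 200 ug/mL.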

Compound 3, half-maximal inhibitory concentration: > 100 ug/mL
Compound 3: a limit, no number; the forecaster's own chance of this, stated with the estimate: 60%; at least 1.1-fold (0.04 log units) between middle value and limit.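

For the compounds shown here, compound 3, like compound 2, reads only as a limit in this assay, so no step from compound 2 to compound 3 can be read: the limit of > 100 ug/mL in this assay, at which 3 of the 3 values shown sit. The compounds shown leave open whether carboxy to ethoxycarbonyl changes cytotoxicity at all.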